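Thiophen-2-yl in place of 4-fluorophenyl, starting from a limit

A few compounds are considered here, and "the series" means these few. Any claim that something is new, unique, unknown or untested is made for them only; others in the source may bear on it.

Compound 1 `O=C(NO)c1ccc(CNCc2nc(-c3ccc(Cl)cc3)no2)cc1`: > 100000 nM, a limit
Compound 2 `O=C(NO)c1ccc(CNCc2nc(-c3ccc(F)cc3)no2)cc1`: > 100000 nM, a limit

In a functional assay on A549 cells (Homo sapiens) for inhibition, read by MTT assay, with a stated time of 72 h (a lower number here means a stronger inhibitor, a higher number a weaker inhibitor), compound 2 gives > 100000 nM, which is a limit and not a number. The next analogue, compound 3 `O=C(NO)c1ccc(CNCc2nc(-c3cccs3)no2)cc1`, carries thiophen-2-yl in place of 4-fluorophenyl on an aromatic carbon. Within the data shown here, only one measured step bears on this change, and it is a step that the two limits leave unreadable from compound 1 to compound 2. It offers no size to carry over, and it concerns a substituent on the phenyl ring, not the ring itself. Because of the limit of > 100000 nM in this assay, at which 2 of the 2 values shown sit, compound 3 is expected to show no step beyond the scatter in this assay, and it will probably also be reported only as a limit. The expected step is a number no higher from compound 2 to compound 3 (the limit leaves the size open). For compound 3 the estimated value is 100000 nM, with an expected range from 30000 nM to 200000 nM.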

Compound 3, half-maximal inhibitory concentration: > 100000 nM
Compound 3: only a limit was reported; the forecaster's own chance of this, stated with the estimate: 75%; the middle value lies on the limit itself.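

Compound 3 gives > 100000 nM in this assay, which is a limit and not a number. The steps from compound 1 and compound 2 to compound 3 cannot be read, because all of them rest on: the limit of > 100000 nM in this assay, at which 3 of the 3 values shown sit.

The compounds shown leave open how strongly any of them acts in this assay, and whether 4-chlorophenyl, 4-fluorophenyl and thiophen-2-yl differ there at all.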